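Swapping Amino for Methyl on an Amide-Type Nitrogen

A few compounds are considered here, and "the series" means these few. Any claim that something is new, unique, unknown or untested is made for them only; others in the source may bear on it.

Measured in a functional assay on A549 cells (Homo sapiens) for inhibition, read by sulforhodamine B assay, with a stated time of 72 h; a higher number here means a weaker inhibitor of growth, a lower number a stronger inhibitor of growth:
- compound 1 `CCOC(=O)/C=C/c1ccncc1-c1ccc2c(cnn2C)c1`: 5030 nM
- compound 2 `NNC(=O)CCc1ccncc1-c1ccc2ccccc2c1`: > 10000 nM
- compound 3 `CCOC(=O)/C=C/c1ccncc1-c1ccc2cc[nH]c2c1`: 5740 nM

In this assay compound 2 gives > 10000 nM, which is a limit and not a number. Compound 1 and compound 3 are the two that return actual numbers, and these lie within the usual scatter of each other. The next structure, compound 4 `CNC(=O)CCc1ccncc1-c1ccc2ccccc2c1`, differs from compound 2 by methyl in place of amino on an amide-type nitrogen. No measured pair sizes this change, so no step beyond the usual scatter is expected in this assay, in either direction, and the expected step is a number no higher from compound 2 to compound 4 (the limit leaves the size open). For compound 4 the estimated value is 10000 nM, with an expected range of 4000 nM to 30000 nM.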

Compound 4, concentration for 50% growth inhibition: 10400 nM
The estimate for compound 4 lay 1.0-fold (0.02 log units) below the measured number, and the stated range covers the measured number.
By their numbers in this assay, from the lowest: compounds 1, 3 and 4 (each within the scatter of the next, the first and the last beyond it).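

No step from compound 2 to compound 4 can be read in this assay, because compound 2 carries only a limit: the limit of > 10000 nM in this assay, at which 1 of the 4 values shown sits.

The compounds shown leave open the size of methyl in place of amino on an amide-type nitrogen.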